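Swapping Octyloxy for Butylsulfanyl on a Shared Core

The source may report more compounds than this note shows. Statements on the series, on what has been measured and on what is new or still open speak of the compounds shown alone.

Compound 2 `CCCCCCCCOc1nc(N)nc2c1ncn2/C=C1/CC1(CO)CO` is one of three analogues built on one core, alongside compound 1 `CCOc1nc(N)nc2c1ncn2/C=C1/CC1(CO)CO` and compound 3 `CN(C)c1nc(N)nc2c1ncn2/C=C1/CC1(CO)CO`. In an ADME assay on BCBL1 cells (Homo sapiens) for cytotoxicity, with a stated time of 7 days (a higher number here means that more compound is tolerated, a lower number that less compound is tolerated), compound 1 reaches only a limit, > 20000 nM. Compound 2 likewise reaches only a limit, > 20000 nM. Compound 3 also gives only a limit, > 20000 nM. All three thus sit at the limit of > 20000 nM in this assay, at which 3 of the 3 values shown sit, and compound 2 stands level with the others there. The steps a step that the two limits leave unreadable from compound 1 to compound 2, a step that the two limits leave unreadable from compound 1 to compound 3 and a step that the two limits leave unreadable from compound 2 to compound 3 cannot be read in size. The unmeasured compound 4 `CCCCSc1nc(N)nc2c1ncn2/C=C1/CC1(CO)CO` differs from compound 2 by butylsulfanyl in place of octyloxy on an aromatic carbon. Among the compounds with values here, no measured step carries a readable size for this change, so the expected step is a step that the limit leaves unreadable from compound 2 to compound 4, none beyond the scatter. Compound 4 is therefore estimated at 40000 nM, between 15000 nM and 150000 nM, most likely reported again as a limit.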

Compound 4, half-maximal cytotoxic concentration: > 20000 nM
Compound 4: a limit, no number; the forecaster's own chance of this, stated with the estimate: 85%; the middle value is on the limit's open side.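

The steps from compound 1, compound 2 and compound 3 to compound 4 cannot be read in size, as all four values are limits: the limit of > 20000 nM in this assay, at which 4 of the 4 values shown sit.

The compounds shown leave open at what concentration, if any, each of the four becomes cytotoxic in this assay.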